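Replacing methyl by propoxy on a chalcone-amide series

The source may report more compounds than this note shows. Statements on the series, on what has been measured and on what is new or still open speak of the compounds shown alone.

Three compounds share one core and differ only in the ring attached to the carbonyl carbon. Compound 1 `COC(=O)c1cc(-c2cccc(NC(=O)c3ccc(/C=C/C(=O)c4cccc(Cl)c4)cc3)c2)on1` carries a 3-chlorophenyl there; in an ADME assay on Vero cells (Chlorocebus sabaeus) for cytotoxicity, read by MTT assay, with a stated time of 72 h (a higher number here means that more compound is tolerated, a lower number that less compound is tolerated), compound 1 gives only a limit of > 2.5 ug/mL. Compound 2 `COC(=O)c1cc(-c2cccc(NC(=O)c3ccc(/C=C/C(=O)c4ccc(C)c(F)c4)cc3)c2)on1` carries a 3-fluoro-4-methylphenyl, and in this assay compound 2 likewise gives a limit of > 50 ug/mL. Compound 3 `COC(=O)c1cc(-c2cccc(NC(=O)c3ccc(/C=C/C(=O)c4ccc(C)cc4)cc3)c2)on1` carries a 4-methylphenyl, and in this assay compound 3 gives a limit of > 80 ug/mL. Because all three readings are limits, the steps a step that the two limits leave unreadable from compound 1 to compound 2, a step that the two limits leave unreadable from compound 1 to compound 3 and a step that the two limits leave unreadable from compound 2 to compound 3 cannot be sized; the evidence (the limit of > 2.5 ug/mL in this assay, at which 1 of the 3 values shown sits), the limit of > 50 ug/mL in this assay, at which 1 of the 3 values shown sits, and the limit of > 80 ug/mL in this assay, at which 1 of the 3 values shown sits, only tells that each compound is tolerated up to where its assay stopped. Compound 3 therefore stands at the highest limit seen, with no true number beside it.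

Compound 4 `CCCOc1ccc(C(=O)/C=C/c2ccc(C(=O)Nc3cccc(-c4cc(C(=O)OC)no4)c3)cc2)cc1` is the next step from compound 3: propoxy in place of methyl on an aromatic carbon. Within the data shown here, none of the measured steps concerns this change, and all of them are unreadable, so no direction can be drawn from them. The expectation is that compound 4 behaves like compound 3, a step of a number no higher from compound 3 to compound 4 (the limit leaves the size open), and most likely the assay again reports a limit. Compound 4 is thus estimated at 80 ug/mL, with a range from 40 ug/mL to 160 ug/mL.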

Compound 4, half-maximal cytotoxic concentration: > 40 ug/mL
Compound 4 was reported as a limit (the forecaster's own chance of this, stated with the estimate: 65%); the middle value is on the limit's open side.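

In this assay compound 4 also gives only a limit, > 40 ug/mL. All four readings are now limits, and the steps from compound 1, compound 2 and compound 3 to compound 4 cannot be read. Still open are the true half-maximal cytotoxic concentrations of these compounds, and whether propoxy in place of methyl changes that concentration at all.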